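A few compounds are considered here, and "the series" means these few. Any claim that something is new, unique, unknown or untested is made for them only; others in the source may bear on it.

Measured in a functional assay on SH-SY5Y cells (Homo sapiens) for antagonist activity, read by cAMP accumulation; on this read-out lower numbers stand for lower potency and higher numbers for higher potency (the scale is a negative logarithm):
- compound 1 `OCCOc1ccc(Cc2ccc(NC3=NCCN3)cc2)cc1` gives 8
- compound 2 `COCCOc1ccc(Cc2ccc(NC3=NCCN3)cc2)cc1` gives 8
- compound 3 `c1cc(NC2=NCCN2)ccc1Cc1ccc(OC2CCCC2)cc1` gives 8.9

Compound 3 stands highest of the three, clearly beyond the scatter from both others. The next structure, compound 4 `c1cc(NC2=NCCN2)ccc1Cc1ccc(OC2CCOCC2)cc1`, differs from it as follows: oxan-4-yl in place of cyclopentyl on an oxygen on an aromatic ring. In words, oxan-4-yl takes the place of cyclopentyl on an oxygen on an aromatic ring.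

Among the compounds with values here, no measured step makes this exact swap, so the evidence is indirect. Exchanging the oxygen-containing chains for cyclopentyl gave a number 0.90 log units higher from compound 1 to compound 3 (beyond the scatter) and a number 0.90 log units higher from compound 2 to compound 3 (beyond the scatter). Capping the chain with methyl gave no change at the digits printed from compound 1 to compound 2 (within the scatter). Oxan-4-yl also contains an oxygen, but it is a ring, unlike either chain, so only part of that gap may carry over.

The expected change in this assay is therefore a modest fall, estimated as a number 0.50 log units lower from compound 3 to compound 4 (beyond the scatter). For compound 4 the expected value is 8.4, with an estimated range from 7.9 to 8.9.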

Compound 4, negative logarithm of the antagonist equilibrium constant: 8.4
The estimate for compound 4 equals the measured number at the digits printed; the measured number falls inside the stated range.
By their numbers in this assay, from the lowest: compounds 1 and 2 (each within the scatter of the next); then compound 4; then compound 3.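

In this assay, replacing cyclopentyl with oxan-4-yl on this oxygen lowers the number only modestly (a number 0.50 log units lower from compound 3 to compound 4 (beyond the scatter)). The oxygen-bearing ring still reads above both open chains (a number 0.40 log units higher from compound 2 to compound 4 (beyond the scatter); a number 0.40 log units higher from compound 1 to compound 4 (beyond the scatter)), so among these four compounds, an oxygen in the group does not by itself bring the number down to the level of the chains. Oxan-4-yl is a six-membered ring and cyclopentyl a five-membered one. This single step changes ring size and adds the oxygen together, and it cannot show how much each contributes.

A cyclohexyl group, a six-membered ring of carbon only, would help separate those two changes, and a piperidin-4-yl group would show what a ring nitrogen does in place of the oxygen. No measurement shown here explains any of these differences.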